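The source may report more compounds than this note shows. Statements on the series, on what has been measured and on what is new or still open speak of the compounds shown alone.

Measured so far:
Compound 1 `Cc1cc(Oc2ccccc2OCCn2ccc(=O)[nH]c2=O)cc2cc(C#N)ccc12`: in a toxicity assay on MT2 cells (Homo sapiens) for cytotoxicity, read by MTT assay (on this read-out higher numbers stand for lower toxicity in this test and lower numbers for higher toxicity in this test), compound 1 gives 6000 nM.
Compound 2 `Cc1cc(Oc2ccccc2OCCn2ccc(=O)[nH]c2=O)c(C)c2cc(C#N)ccc12`: in this assay compound 2 gives only a limit, > 100000 nM.
Compound 3 `COc1cc(Oc2ccccc2OCCn2ccc(=O)[nH]c2=O)c(C)c2cc(C#N)ccc12`: in this assay compound 3 gives only a limit, > 100000 nM.

Compound 2 thus stands at the upper edge of this assay, the point where most of these values sit (the limit of > 100000 nM in this assay, at which 2 of the 3 values shown sit), and no number is known for it. Compound 4 `Cc1cc(Oc2ccc(F)cc2OCCn2ccc(=O)[nH]c2=O)c(C)c2cc(C#N)ccc12` differs from compound 2 by fluoro in place of hydrogen on an aromatic carbon. Among the measured compounds shown here, no measured step involves a fluoro group. The step of an at least 16-fold higher number from compound 1 to compound 2 (1.22 log units; beyond the scatter) was large, and the step that the two limits leave unreadable from compound 2 to compound 3 is unreadable, both values being limits. With compound 2 already at the limit, any rise could not be read, and nothing here points to a fall. Compound 4 is therefore expected to give about 100000 nM in this assay, between 30000 nM and 300000 nM, an expected step of a number no higher from compound 2 to compound 4 (the limit leaves the size open).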

Compound 4, half-maximal cytotoxic concentration: > 100000 nM
Compound 4: a limit, no number (the forecaster's own chance of this, stated with the estimate: 70%); the middle value lies on the limit itself.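

Compound 2 and compound 4 each give only a limit, not a number, so the step between them cannot be read: the limit of > 100000 nM in this assay, at which 3 of the 4 values shown sit.

The compounds shown leave open whether fluoro in place of hydrogen on an aromatic carbon changes toxicity at all.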